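The source may report more compounds than this note shows. Statements on the series, on what has been measured and on what is new or still open speak of the compounds shown alone.

Three compounds share one core and differ only in the group attached to one aromatic carbon of it. Compound 1 `Nc1cc(N)c2nc(-c3ccccc3)c(NCc3ccc(F)cc3)nc2c1` carries a (4-fluorobenzyl)amino group there; in a functional assay on SNB-19 cells (Homo sapiens) for inhibition, read by sulforhodamine B assay, with a stated time of 48 h (a higher number here means that more compound is tolerated, a lower number that less compound is tolerated), compound 1 gives 52500 nM. Compound 3 `Nc1cc(N)c2nc(-c3ccccc3)c(Oc3ccc(F)cc3)nc2c1` carries a 4-fluorophenoxy group in that place, and in this assay compound 3 gives 66100 nM. The step of a 1.3-fold higher number from compound 1 to compound 3 (0.10 log units; within the scatter) means compound 3 stands alongside compound 1 rather than apart from it. Compound 2 `Nc1cc(N)c2nc(-c3ccccc3)c(Sc3ccc(Cl)c(Cl)c3)nc2c1` carries a (3,4-dichlorophenyl)sulfanyl group. For compound 2 the assay reports only a limit, < 100000 nM, and no number (the limit of < 100000 nM in this assay, at which 1 of the 3 values shown sits).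

Compound 4 `Nc1cc(N)c2nc(-c3ccccc3)c(Sc3ccc(F)cc3)nc2c1` has not been measured. The change from compound 3 to compound 4 is (4-fluorophenyl)sulfanyl in place of 4-fluorophenoxy on an aromatic carbon. Going by the values given here, of the measured steps, only a 1.3-fold higher number from compound 1 to compound 3 (0.10 log units; within the scatter) gives a readable size, and it concerns a different exchange; the sulfur-linked compound 2 offers a limit, so no measured step tells how swapping oxygen for sulfur behind the same ring plays out. On that basis the step of a 1.1-fold lower number from compound 3 to compound 4 (0.04 log units; within the scatter) is expected to be none beyond the scatter. Compound 4 is therefore estimated at 60000 nM, with a range from 25000 nM to 150000 nM.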

Compound 4, concentration lethal to 50% of the cells: 87100 nM
Compound 4: middle estimate off by 1.5-fold (0.16 log units), on the low side; the range from low to high includes it.
By their numbers in this assay, from the lowest: compounds 1, 3 and 4 (each within the scatter of the next).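

Going by these compounds alone, replacing the oxygen link with a sulfur link while keeping the 4-fluorophenyl ring isolates the linking atom at this position for the first time, and in this assay the exchange gives a 1.3-fold higher number from compound 3 to compound 4 (0.12 log units; within the scatter). The wider exchange of the (4-fluorobenzyl)amino group for the (4-fluorophenyl)sulfanyl group gives a 1.7-fold higher number from compound 1 to compound 4 (0.22 log units; within the scatter), so neither the linking atom nor the wider exchange separates these compounds by more than the usual variation between repeated measurements. The step between compound 2 and compound 4 cannot be read, since compound 2 is recorded only as a limit: the limit of < 100000 nM in this assay, at which 1 of the 4 values shown sits.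

Within the data shown here, every readable step so far lies within the scatter, so it remains open whether any group at this position can move the number beyond it. Also open is how the position responds to groups unlike the aromatic rings shown here, such as a simple amine, a carboxylic acid or a longer alkyl chain, and whether the 3,4-dichlorophenyl ring on sulfur truly differs from the 4-fluorophenyl ring.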